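This account rests on a few compounds, and the source may have more. Where it says the series, first, only, none or still open, it means among the compounds named here.

The series shares one core, seen in compound 1 `COc1ccc2nc(C)cc(OC3CCN(c4ccccc4)C3=O)c2c1` and compound 2 `COc1ccc2nc(C)cc(OCC(=O)NCc3cc(C)cc(C)c3)c2c1`. In a toxicity assay on HepG2 cells (Homo sapiens) for inhibition, read by CellTiter-Glo, with a stated time of 48 h (on this read-out higher numbers stand for weaker inhibition and lower numbers for stronger inhibition), compound 1 gives 100000 nM. Compound 2 reaches only a limit of the assay, > 100000 nM. That reading places compound 2 at the limit of > 100000 nM in this assay, at which 1 of the 2 values shown sits, so no number is known for it. Compound 3 `COc1ccc2nc(C)cc(OCC(=O)Nc3cc(F)cc(F)c3)c2c1` differs from compound 2 at one place: 3,5-difluorophenyl in place of 3,5-dimethylbenzyl on an amide-type nitrogen. Both measured compounds sit at the weak end of this assay, and no step beyond the scatter is expected in this assay. For compound 3 the expected value is 100000 nM, within 50000 nM to 300000 nM, and the step of a number no higher from compound 2 to compound 3 (the limit leaves the size open) is expected to be flat.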

Compound 3, half-maximal inhibitory concentration: > 100000 nM
Compound 3: a limit, no number; the forecaster's own chance of this, stated with the estimate: 70%; the middle value sits exactly at the limit.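

Compound 3 gives only a limit in this assay, > 100000 nM. Among these compounds, compound 2 also stands at a limit, so no step between compound 2 and compound 3 can be read. The compounds shown leave open whether 3,5-difluorophenyl in place of 3,5-dimethylbenzyl changes the read-out at all.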